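Benzyl thioethers on a dinitrophenyl triazole core: cytotoxicity

The source may hold more compounds than are shown below. What is called first, only, known or untested is meant among the compounds shown, and "the series" means these compounds.

Measured so far:
Compound 1 `O=[N+]([O-])c1cc(CSc2nnc(-c3ccc(Cl)cc3)n2Cc2ccccc2)cc([N+](=O)[O-])c1` — in an ADME assay on A-431 cells (Homo sapiens) for cytotoxicity, with a stated time of 48 h (a lower number here means a stronger inhibitor, a higher number a weaker inhibitor), compound 1 gives > 30000 nM, a limit of the assay rather than a number.
Compound 2 `Cn1c(SCc2ccccc2)nnc1-c1cc([N+](=O)[O-])cc([N+](=O)[O-])c1` — in this assay compound 2 gives > 30000 nM, again a limit.
Compound 3 `CSc1nnc(-c2cc([N+](=O)[O-])cc([N+](=O)[O-])c2)n1Cc1ccccc1` — in this assay compound 3 gives > 30000 nM, also a limit.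

All three compounds share a core carrying a dinitrophenyl group and a sulfur-linked substituent, and none of them reaches a measurable value: each sits at the limit of > 30000 nM in this assay, at which 3 of the 3 values shown sit. Compound 3, the smallest of the three, therefore stands at the same limit as the others, so no ordering among them can be read from these numbers.

Compound 4 `O=[N+]([O-])c1cc(-c2nnc(SCc3ccc(Cl)cc3)n2Cc2ccccc2)cc([N+](=O)[O-])c1` has not yet been tested in this assay. It differs from compound 3 in one place: 4-chlorophenyl in place of hydrogen on a saturated chain carbon bound to a sulfur. Among the compounds with values here, because no step between two measured compounds is available, there is nothing to calibrate the size of this change against, and the fact that every measured compound sits at the limit suggests nothing beyond the usual scatter. The expected change is a step that the limit leaves unreadable from compound 3 to compound 4. Compound 4 is therefore expected to give 40000 nM in this assay, most likely reported as a limit, with a plausible range from 15000 nM to 100000 nM.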

Compound 4, half-maximal inhibitory concentration: > 30000 nM
Compound 4 ended at the assay's limit; the forecaster's own chance of this, stated with the estimate: 85%; the middle value is on the limit's open side.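

No step can be read between compound 3 and compound 4, since both values are limits of the assay rather than numbers: the limit of > 30000 nM in this assay, at which 4 of the 4 values shown sit.

The compounds shown leave open how these four rank against one another in this assay, and which change to the shared core, if any, would give a measurable value.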